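This account rests on a few compounds, and the source may have more. Where it says the series, first, only, none or still open, it means among the compounds named here.

Compound 1 `Cc1ccccc1-c1nn(-c2cc(F)ccc2F)cc1CNCCN1CCN(C)CC1`: in an ADME assay on Huh-7 cells (Homo sapiens) for cytotoxicity (a lower number here means that less compound is tolerated, a higher number that more compound is tolerated), compound 1 gives > 20000 nM, which is a limit of the assay rather than a number.
Compound 2 `Cc1ccccc1-c1nn(-c2ccc(F)c(F)c2)cc1CNCCN1CCN(C)CC1`: in this assay compound 2 gives > 20000 nM, again a limit.
Compound 3 `CCOC(=O)Cn1cc(CNCCN2CCN(C)CC2)c(-c2ccccc2C)n1`: in this assay compound 3 gives > 20000 nM, also a limit.

Compound 3 therefore stands only at a limit, and the two other values shown are limits as well, all three sitting at the limit of > 20000 nM in this assay, at which 3 of the 3 values shown sit. The change on the way to compound 4 `Cc1ccccc1-c1nn(-c2cccc(Cl)c2)cc1CNCCN1CCN(C)CC1` is 3-chlorophenyl in place of (ethoxycarbonyl)methyl on an aromatic nitrogen. The measured steps that touch the same position are a step that the two limits leave unreadable from compound 1 to compound 3 and a step that the two limits leave unreadable from compound 2 to compound 3; both have their two ends at the limit, so their size cannot be read. The step that the two limits leave unreadable from compound 1 to compound 2 is unreadable for the same reason. For the measured compounds named here, no measured step here shows a movement away from the limit, so the expected step is a step that the limit leaves unreadable from compound 3 to compound 4, none beyond the scatter, and the value of compound 4 is most likely to come back as a limit as well. Compound 4 is expected to give 25000 nM, with a range from 12000 nM to 60000 nM.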

Compound 4, half-maximal cytotoxic concentration: 16000 nM
Estimate against measurement, compound 4: 1.6-fold (0.19 log units) above; low and high end bracket the measured number.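

For the compounds shown here, with 3-chlorophenyl on this aromatic nitrogen, this assay gives its only value here that is a number rather than a limit, so this position now has one readable end. The readable steps are an at least 1.2-fold lower number from compound 3 to compound 4 (0.09 log units; that floor lies within the scatter), an at least 1.2-fold lower number from compound 2 to compound 4 (0.09 log units; that floor lies within the scatter) and an at least 1.2-fold lower number from compound 1 to compound 4 (0.09 log units; that floor lies within the scatter); each is only a floor, so none of them establishes a real drop in the amount of compound tolerated. The steps among compound 1, compound 2 and compound 3 still cannot be read, and most values here remain at the limit: the limit of > 20000 nM in this assay, at which 3 of the 4 values shown sit.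

On these data alone, whether the chlorine matters, or only where it sits on the ring, stays open. So does what a plain phenyl, a 4-chlorophenyl or a carboxylic acid in place of the ethyl ester would give on this nitrogen.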